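A few compounds are considered here, and "the series" means these few. Any claim that something is new, unique, unknown or untested is made for them only; others in the source may bear on it.

Measured compounds:
compound 1 `CC(O)CSc1nc(NCc2ccc(-c3ccccn3)cc2)c2[nH]nc(C(C)C)c2n1` — 62 nM
compound 2 `CC(C)c1n[nH]c2c(NCc3ccc(-c4ccccn4)cc3)nc(SCC3CNC(=O)O3)nc12` — 80 nM
compound 3 `CNCCSc1nc(NCc2ccc(-c3ccccn3)cc2)c2[nH]nc(C(C)C)c2n1` — 56 nM

All three share one core and differ only in the group on a saturated chain carbon bound to a sulfur. In a functional assay on HT cells (Homo sapiens) for antiproliferative activity, read by fluorescence, with a stated time of 72 h (on this read-out higher numbers stand for weaker inhibition of growth and lower numbers for stronger inhibition of growth), compound 1 gives 62 nM, compound 2 gives 80 nM and compound 3 gives 56 nM. The steps are small: a 1.3-fold higher number from compound 1 to compound 2 (0.11 log units; within the scatter), a 1.1-fold lower number from compound 1 to compound 3 (0.04 log units; within the scatter) and a 1.4-fold lower number from compound 2 to compound 3 (0.15 log units; within the scatter), each within the scatter. Compound 3 carries the lowest number of the three, yet neither of its steps to compound 1 or compound 2 is beyond the scatter, so nothing separates it from them.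

Compound 4 `COCSc1nc(NCc2ccc(-c3ccccn3)cc2)c2[nH]nc(C(C)C)c2n1` continues the same point of variation: methoxy in place of (methylamino)methyl on a saturated chain carbon bound to a sulfur. Every measured step at this position, whatever group entered, stayed within the scatter, and the hydrogen-bond donor lost here is also absent in compound 1 at the same place. On that basis no step beyond the scatter is expected in this assay, with a 1.1-fold higher number from compound 3 to compound 4 (0.04 log units; within the scatter) the expected change. Compound 4 is therefore estimated at 62 nM, within 30 nM to 130 nM.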

Compound 4, concentration for 50% growth inhibition: 340 nM
Beside the measured number, compound 4's estimate is 5.5-fold (0.74 log units) below it; measured number above the stated range.
By their numbers in this assay, from the lowest: compounds 3, 1 and 2 (each within the scatter of the next); then compound 4.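

In this assay, this position proves sensitive to the group it carries: methoxy on a saturated chain carbon bound to a sulfur gives a 6.1-fold higher number from compound 3 to compound 4 (0.78 log units; beyond the scatter), a 5.5-fold higher number from compound 1 to compound 4 (0.74 log units; beyond the scatter) and a 4.3-fold higher number from compound 2 to compound 4 (0.63 log units; beyond the scatter). Among the compounds shown here, these are the first steps beyond the scatter at this place, so the agreement among 1-hydroxyethyl, 2-oxo-1,3-oxazolidin-5-yl and (methylamino)methyl does not extend to every small group. Against compound 3, the change takes the group from 3 heavy atoms to 2 and from 1 hydrogen-bond donor to 0, and this single pair cannot show which difference, if either, matters.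

No supporting data bear on why the number rises at compound 4. As far as these compounds go, whether a longer ether such as 2-methoxyethyl or a primary amine at this place would give a number within the scatter of compound 3 remains open.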